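The compounds below may be only part of what the source reports. "The series", "measured", "known", "first", "only" and "open" are said of these compounds alone.

Compound 3 `COc1ccc(-c2cnc(NC(=O)c3cccc(O)c3)n2C)cc1` is one of three compounds that have been measured so far in a toxicity assay on THP-1 cells (Homo sapiens) for inhibition; on this read-out higher numbers stand for lower toxicity in this test and lower numbers for higher toxicity in this test. In this assay compound 3 gives > 100000 nM, and this is a limit of the assay rather than a number. Compound 1 `Cn1c(-c2ccccc2)cnc1NC(=O)c1ncc[nH]1` gives > 100000 nM in this assay, again a limit. Compound 2 `COc1ccc(-c2cnc(NC(=O)CCc3ccccc3)n2C)cc1` gives > 100000 nM in this assay, also a limit. Compound 3 therefore stands exactly where its two companions stand, at the limit of > 100000 nM in this assay, at which 3 of the 3 values shown sit. For the measured compounds named here, the single measured step between compounds that differ in one place, a step that the two limits leave unreadable from compound 2 to compound 3, has no readable size, since both of its ends are limits.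

Compound 4 `COc1ccc(-c2cnc(NC(=O)c3ncc[nH]3)n2C)cc1` has not yet been measured. It differs from compound 3 in one place: 1H-imidazol-2-yl in place of 3-hydroxyphenyl on a carbonyl carbon. Going by the values given here, no measured step changes exactly this group, so the only step that bears on the change is a step that the two limits leave unreadable from compound 2 to compound 3, and its size cannot be read. Compound 1, which also carries 1H-imidazol-2-yl on a carbonyl carbon, gives > 100000 nM in this assay, a limit.

The step from compound 3 to compound 4 is expected to be a step that the limit leaves unreadable from compound 3 to compound 4, nothing beyond the scatter. Compound 4 is expected to give about 150000 nM in this assay, estimated between 80000 nM and 400000 nM, most likely reported again only as a limit.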

Compound 4, half-maximal cytotoxic concentration: > 100000 nM
Compound 4: only a limit was reported (the forecaster's own chance of this, stated with the estimate: 85%); the middle value is on the limit's open side.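

The steps from compound 1, compound 2 and compound 3 to compound 4 cannot be read in this assay, since compound 4, like the other three, is reported only as a limit: the limit of > 100000 nM in this assay, at which 4 of the 4 values shown sit. The compounds shown leave open where the true values lie beyond that limit, and so whether any of these changes matters in this read-out.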